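The compounds below may be only part of what the source reports. "The series", "measured", "known", "first", "only" and "open" are said of these compounds alone.

Measured so far:

- compound 1, `C[Se]c1nc([Se]C)c2cccnc2n1`: in a functional assay on CCRF-CEM cells (Homo sapiens) for cytotoxicity, read by MTT assay, with a stated time of 72 h (a higher number here means a weaker inhibitor of growth, a lower number a stronger inhibitor of growth), compound 1 gives "not determined" (no result reported)
- compound 2, `CCCCC[Se]c1nc([Se]CCCCC)c2ccccc2n1`: in this assay compound 2 gives > 100000 nM

Compound 1 carries methylselanyl groups on its core, and for compound 1 no figure in this assay was reported. Compound 2 carries two pentylselanyl groups on a different core, and its entry in this assay is a limit rather than a number: it sits at the limit of > 100000 nM in this assay, at which 1 of the 2 values shown sits, so compound 2 did not reach total growth inhibition within the tested range. On the numbers shown, then, compound 2 stands at the limit, with one further entry beside it that gives no single number.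

Compound 3, `CCCCC[Se]c1nc(NCc2ccccc2)c2ccccc2n1`, differs from compound 2 by a group of 8 heavy atoms (7 carbon, 1 nitrogen; one six-membered aromatic ring of carbon only) in place of a group of 6 heavy atoms (5 carbon, 1 selenium; no ring), on an aromatic carbon. For the measured compounds named here, no measured pair separates the effect of such a change, so the expected size of the step in this assay rests on compound 2 alone, whose limit value > 100000 nM offers no direction. The step from compound 2 to compound 3 is estimated at an at least 1.6-fold lower number from compound 2 to compound 3 (0.22 log units; that floor lies within the scatter). Compound 3 is expected to give about 60000 nM in this assay, with a range from 15000 nM to 200000 nM.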

Compound 3, concentration for total growth inhibition: 72500 nM
Compound 3: the middle estimate sits 1.2-fold (0.08 log units) below what was measured; the measured number falls inside the stated range.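

Putting benzylamino in place of one pentylselanyl group on this aromatic carbon gives the only single number among the compounds shown in this assay, so total growth inhibition now falls within the tested range. A pentylselanyl group at this position is therefore not needed for a measurable result, at least while the other pentylselanyl group stays in place. The change amounts to an at least 1.3-fold lower number from compound 2 to compound 3 (0.13 log units; that floor lies within the scatter), but this is only a floor, and the true size of the step remains unknown because compound 2 stands at a limit: the limit of > 100000 nM in this assay, at which 1 of the 3 values shown sits.

As far as these compounds go, it remains open whether the result depends on the aromatic ring of benzylamino or on the nitrogen that links it to the core, and a plain amine or a butylamino chain at this position would help separate the two. Also open, from the compounds shown here alone, is what the remaining pentylselanyl group contributes, which could be tested with a longer chain or an amine in its place.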